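A few compounds are considered here, and "the series" means these few. Any claim that something is new, unique, unknown or untested is made for them only; others in the source may bear on it.

Measured so far in an assay on isolated protein for displacement of a labelled ligand from D(4) dopamine receptor (Homo sapiens); on this read-out higher numbers stand for weaker inhibition and lower numbers for stronger inhibition:
- compound 1, `O=C(NC1CCN(Cc2ccc(Br)cc2)CC1)c1cccc2ccccc12`, gives 44 nM
- compound 2, `O=C(NC1CCN(Cc2cccc(Cl)c2)CC1)c1ccc2ccccc2c1`, gives 54 nM

Both compounds share the same core, an amide of a naphthalene carboxylic acid linked to a piperidine that carries a substituted benzyl group. Compound 2 has the higher of the two numbers in this assay, but its gap to compound 1 is within the usual scatter of repeated measurements, so the two are best read as equal on the evidence shown.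

Compound 3, `Cc1cccc(CN2CCC(NC(=O)c3ccc4ccccc4c3)CC2)c1`, has not been measured. It differs from compound 2 in one place: methyl in place of chloro on an aromatic carbon. Both groups are single heavy atoms with no hydrogen-bond donors or acceptors and no charge, so the shape of the molecule is almost unchanged. For the measured compounds named here, no measured pair shows what this exchange does to the inhibition constant, so the expectation rests on the small size of the change alone: the step from compound 2 to compound 3 is expected to be a 1.3-fold higher number from compound 2 to compound 3 (0.11 log units; within the scatter), not beyond the scatter in either direction. Compound 3 is therefore estimated at 70 nM, with a range from 30 nM to 170 nM.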

Compound 3, inhibition constant: 11 nM
Estimate against measurement, compound 3: 6.4-fold (0.80 log units) above; measured number below the stated range.
By their numbers in this assay, from the lowest: compound 3; then compounds 1 and 2 (each within the scatter of the next).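

For the compounds shown here, the exchange of 3-chlorobenzyl for 3-methylbenzyl gives a 4.9-fold lower number from compound 2 to compound 3 (0.69 log units; beyond the scatter) in this assay, the only step so far between compounds that differ in one place. It shows that this position is sensitive: replacing one heavy atom with another changes the inhibition constant by more than the scatter, even though the counts of hydrogen-bond donors and acceptors and the net charge stay the same. Nothing available explains why methyl gives the lower number here.

A single step at a single position cannot show whether the trend extends beyond methyl, so an ethyl group, a methoxy group or an amine at this same place could lower the number further or raise it again. Going by these compounds, it also remains open whether methyl in place of chloro would have a similar effect at another position on the aromatic ring, or on a compound with a different substituted benzyl group.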